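The source may hold more compounds than are shown below. What is called first, only, known or untested is meant among the compounds shown, and "the series" means these compounds.

Measured so far in a functional assay on DU-145 cells (Homo sapiens) for inhibition, read by MTT assay, with a stated time of 24 h; on this read-out lower numbers stand for stronger inhibition and higher numbers for weaker inhibition:
compound 1, `CCOC(=O)C1=Cc2ccccc2OC1(OCc1cn(CC(=O)Nc2cccc(F)c2)nn1)C(F)(F)F` — > 150000 nM
compound 2, `CCOC(=O)C1=Cc2ccccc2OC1(OCc1cc(-c2ccc(C)cc2)no1)C(F)(F)F` — > 150000 nM

Compound 1 (`CCOC(=O)C1=Cc2ccccc2OC1(OCc1cn(CC(=O)Nc2cccc(F)c2)nn1)C(F)(F)F`) gives in this assay the value > 150000 nM, which is a limit of the assay and not a number. Compound 2 (`CCOC(=O)C1=Cc2ccccc2OC1(OCc1cc(-c2ccc(C)cc2)no1)C(F)(F)F`) gives > 150000 nM, again a limit rather than a number. Going by the values given here, compound 1 therefore stands together with the only other value shown, both of them resting on the same limit: the limit of > 150000 nM in this assay, at which 2 of the 2 values shown sit. Among the compounds with values here, no step between measured compounds is available, so no direction of change can be read from these two entries.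

Compound 3 (`CCOC(=O)C1=Cc2ccccc2OC1(OCc1cn(-c2ccc(F)c(Cl)c2)nn1)C(F)(F)F`) has not yet been measured. Relative to compound 1 the change is 3-chloro-4-fluorophenyl in place of ((3-fluorophenyl)carbamoyl)methyl on an aromatic nitrogen. With both measured values sitting on the limit, the step of a number no higher from compound 1 to compound 3 (the limit leaves the size open) is expected to be none beyond the scatter, and the most probable outcome is that the assay again reports only a limit. The estimate for compound 3 in this assay is 150000 nM, with a range from 50000 nM to 400000 nM.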

Compound 3, half-maximal inhibitory concentration: 21500 nM
The estimate for compound 3 lay 7.0-fold (0.84 log units) above the measured number; the whole stated range lies above it.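

Placing 3-chloro-4-fluorophenyl in place of ((3-fluorophenyl)carbamoyl)methyl on the aromatic nitrogen of the five-membered ring gives an at least 6.9-fold lower number from compound 1 to compound 3 (0.84 log units; beyond the scatter) in this assay, showing that the group on this nitrogen can move the read-out on the shared core. Compound 1 gives > 150000 nM, which is a limit of the assay and not a number. Compound 3 is the only compound shown with a true number in this assay, so the step has a known lower bound on its size, while its full size stays open: the limit of > 150000 nM in this assay, at which 2 of the 3 values shown sit.

The change removes the amide-bearing chain and alters the halogens on the aromatic ring at once, so the compounds shown cannot separate the contribution of the amide from that of the chlorine. As far as these compounds go, it also stays open whether an unsubstituted phenyl, a 3-fluorophenyl set directly on the nitrogen, or a phenyl bearing an amine or a carboxylic acid would give a number like that of compound 3 or return to the limit.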